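A Carbonyl Substituent Swap Without a Measured Precedent

The source may report more compounds than this note shows. Statements on the series, on what has been measured and on what is new or still open speak of the compounds shown alone.

Compound 2 `COc1cc(Cl)cc(-c2nn(-c3cccc(NC(=O)Nc4ccc(Cl)c(Cl)c4)c3)cc2-c2ccncc2)c1` sits highest of the two numbers in a functional assay on SNB-75 cells (Homo sapiens) for inhibition, read by sulforhodamine B assay, with a stated time of 48 h, tested at 0.1 uM (a lower number here means a stronger effect, a higher number a weaker effect of the compound at the concentration tested), where compound 2 gives 90%. Among the measured compounds shown here, compound 1 `O=C(Nc1cccc(-n2cc(-c3ccncc3)c(-c3cc(O)cc(Cl)c3)n2)c1)Nc1ccc(Cl)c(Cl)c1` gives 52%, and the only measured step, a number 38 percentage points higher from compound 1 to compound 2 (beyond the scatter), concerns methyl in place of hydrogen on an oxygen on an aromatic ring. Compound 3 `COc1cc(Cl)cc(-c2nn(-c3cccc(NC(=O)c4cccc(C(F)(F)F)c4)c3)cc2-c2ccncc2)c1` alters a different place: 3-(trifluoromethyl)phenyl in place of (3,4-dichlorophenyl)amino on a carbonyl carbon. For the measured compounds named here, no measured step touches the carbonyl carbon, so this change has no precedent among the measured compounds, and the expectation for compound 3 is a step of a number 5 percentage points lower from compound 2 to compound 3 (within the scatter), roughly none beyond the scatter. Compound 3 is therefore estimated at 85%, ranging from 55% to 105%.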

Compound 3, a percentage reported as activity, at one concentration (the size of the read-out at that concentration, not a potency): 54%
Compound 3: middle estimate off by 31 percentage points, on the high side; measured number outside the range, below it.
By their numbers in this assay, from the lowest: compounds 1 and 3 (each within the scatter of the next); then compound 2.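

In this assay, the carbonyl carbon proves a responsive place: a number 36 percentage points lower from compound 2 to compound 3 (beyond the scatter), a stronger effect at the concentration tested. The change removes the amino nitrogen with its hydrogen-bond donor and also replaces the ring's substituents, so this single step cannot credit either alone. Nothing available accounts for the step.

Still open, on these data alone, is how 3-(trifluoromethyl)phenylamino or 3,4-dichlorophenyl on the carbonyl carbon would read, since either would separate those two changes. Also open, as far as these compounds go, is whether hydrogen in place of methyl on the oxygen would add to this step.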